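Series notes: cyano in place of hydroxy, compound 3

A few compounds are considered here, and "the series" means these few. Any claim that something is new, unique, unknown or untested is made for them only; others in the source may bear on it.

Of the compounds shown here, two have been measured in an ADME assay on J774 cells (Mus musculus) for cytotoxicity, read by MTT assay, with a stated time of 48 h, tested at 100 ug/mL; a lower number here means a stronger effect, a higher number a weaker effect of the compound at the concentration tested. Compound 1 `O=C(N/N=C/c1ccc(F)cc1)c1cnccn1` gives 69%. Compound 2 `O=C(N/N=C/c1ccc(O)cc1)c1cnccn1` gives 81%. Compound 2 therefore stands highest of the two numbers; its nearest neighbour is compound 1, and the step of a number 12 percentage points higher from compound 1 to compound 2 (beyond the scatter) shows that exchanging the group para to a large group on that ring moves the read-out beyond the scatter, toward a weaker effect.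

Compound 3 `N#Cc1ccc(/C=N/NC(=O)c2cnccn2)cc1` has not been measured. It differs from compound 2 as follows: cyano in place of hydroxy on an aromatic carbon. For the measured compounds named here, no measured step concerns cyano itself. Going by the values given here, the only known step, a number 12 percentage points higher from compound 1 to compound 2 (beyond the scatter), bears on it indirectly: it shows that a single exchange of the group para to a large group is enough to shift this assay by a modest amount, and that the one compound lacking the hydroxy, compound 1, lies lower. A modest downward step a number 9 percentage points lower from compound 2 to compound 3 (within the scatter) is expected because compound 1 gives 69% and is the other compound without hydroxy. Compound 3 is accordingly estimated at 72%, with a range from 55% to 88%.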

Compound 3, a percentage reported as activity, at one concentration (the size of the read-out at that concentration, not a potency): 100%
Estimate against measurement, compound 3: 28 percentage points below; measured number outside the range, above it.
By their numbers in this assay, from the lowest: compound 1; then compound 2; then compound 3.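

In this assay, the place para to a large group on the six-membered aromatic ring of carbon only spans a wider range than the first pair showed: cyano in place of hydroxy gives a number 19 percentage points higher from compound 2 to compound 3 (beyond the scatter), and cyano in place of fluoro gives a number 31 percentage points higher from compound 1 to compound 3 (beyond the scatter). Compound 3 therefore shows the weakest effect of the three at the concentration tested, and the two groups other than hydroxy lie at opposite ends of the order, so the absence of hydroxy does not by itself bring a lower number, as the contrast of fluoro in compound 1 with cyano in compound 3 shows. No measurement at hand accounts for this order.

As far as these compounds go, three groups at one place cannot show which feature of a group sets the number, and it remains open where an amine, a methoxy group or a carboxylic acid in the same place would fall relative to fluoro, hydroxy and cyano. From the compounds shown here alone, it also remains open whether the cyano step would hold with cyano elsewhere on the ring or with another change to the shared core.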